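Swapping the benzyl amide aryl: methyl out, dichloro in

A few compounds are considered here, and "the series" means these few. Any claim that something is new, unique, unknown or untested is made for them only; others in the source may bear on it.

Measured compounds:
compound 1, `C[C@H](NC(=O)C(=O)NCC1(c2ccccc2)CC1)C(=O)N[C@@H](CC(=O)O)C(=O)COc1c(F)c(F)cc(F)c1F`: 27 nM
compound 2, `Cc1ccc(CNC(=O)C(=O)N[C@@H](C)C(=O)N[C@@H](CC(=O)O)C(=O)COc2c(F)c(F)cc(F)c2F)cc1`: 50 nM
compound 3, `C[C@H](NC(=O)C(=O)NCc1ccccc1F)C(=O)N[C@@H](CC(=O)O)C(=O)COc1c(F)c(F)cc(F)c1F`: 207 nM

In a functional assay on Jurkat cells (Homo sapiens) (a lower number here means a stronger inhibitor, a higher number a weaker inhibitor), compound 2 gives 50 nM, the second highest of the three numbers. The step of a 1.9-fold higher number from compound 1 to compound 2 (0.27 log units; within the scatter) lies within the scatter, so compound 1 and compound 2 cannot be told apart, whereas a 4.1-fold higher number from compound 2 to compound 3 (0.62 log units; beyond the scatter) lies beyond it and marks compound 3 as the weakest of the three. Compound 4, `C[C@H](NC(=O)C(=O)NCc1cc(Cl)cc(Cl)c1)C(=O)N[C@@H](CC(=O)O)C(=O)COc1c(F)c(F)cc(F)c1F`, differs from compound 2 in one place: 3,5-dichlorophenyl in place of 4-methylphenyl on a saturated chain carbon bound to an amide-type nitrogen. The measured steps that bear on this change are those that alter the same aryl group on the saturated chain carbon bound to an amide-type nitrogen: a 4.1-fold higher number from compound 2 to compound 3 (0.62 log units; beyond the scatter) and a 7.7-fold higher number from compound 1 to compound 3 (0.88 log units; beyond the scatter), both modest losses when a halogenated phenyl replaced an unhalogenated one. A halogen pattern has therefore so far weakened inhibition, though at a different position, so only a small step toward a higher number, or none beyond the scatter, is expected, a 1.5-fold higher number from compound 2 to compound 4 (0.18 log units; within the scatter). Compound 4 is estimated at 75 nM, with a range from 25 nM to 250 nM.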

Compound 4, half-maximal inhibitory concentration: 23 nM
For compound 4 the middle estimate is 3.3-fold (0.51 log units) above the measured one, and the stated range ends above it.
By their numbers in this assay, from the lowest: compounds 4, 1 and 2 (each within the scatter of the next, the first and the last beyond it); then compound 3.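

In this assay the exchange of 4-methylphenyl for 3,5-dichlorophenyl brings a 2.2-fold lower number from compound 2 to compound 4 (0.34 log units; beyond the scatter) and so shows that a halogenated phenyl on this saturated chain carbon need not cost inhibition. Halogen alone does not set the outcome here, since the two halogenated groups are far apart, with a 9.0-fold lower number from compound 3 to compound 4 (0.95 log units; beyond the scatter) on going from 2-fluorophenyl to 3,5-dichlorophenyl. The step of a 1.2-fold lower number from compound 1 to compound 4 (0.07 log units; within the scatter) leaves compound 4 and compound 1 indistinguishable, so an aryl group carried directly on the benzylic carbon and a 1-phenylcyclopropyl group can serve equally well at this place.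

From the compounds shown here alone, whether both chlorines are needed remains open, as does whether 3-chlorophenyl or 3,5-dimethylphenyl would match 3,5-dichlorophenyl. Nothing available explains why the dichloro group performs as it does.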